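Reversing the enone chain on a trimethoxyphenyl core

This account rests on a few compounds, and the source may have more. Where it says the series, first, only, none or still open, it means among the compounds named here.

Compound 1, `COc1cc(-c2cc(C(=O)/C=C/c3ccc(Cl)cc3)nc3cc(-c4ccccc4)nn23)cc(OC)c1OC`: 23800 nM
Compound 2, `COc1ccc(-c2cc(C(=O)/C=C/c3ccc(Cl)cc3)nc3cc(-c4ccccc4)nn23)cc1OC`: 22000 nM
Compound 3, `COc1ccc(/C=C/C(=O)c2cc(-c3cc(OC)c(OC)c(OC)c3)n3nc(-c4ccccc4)cc3n2)cc1OC`: 20500 nM

These three compounds were tested in a functional assay on A549 cells (Homo sapiens) for antiproliferative activity, read by MTT assay, with a stated time of 24 h; a higher number here means a weaker inhibitor, a lower number a stronger inhibitor. Compound 1 gives the highest of the three numbers, but its neighbours sit close: a 1.1-fold lower number from compound 1 to compound 2 (0.03 log units; within the scatter), and a 1.2-fold lower number from compound 1 to compound 3 (0.06 log units; within the scatter). Neither step leaves the scatter, so the three compounds cannot be told apart on these data.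

Compound 4, `COc1cc(-c2cc(/C=C/C(=O)c3ccc(C)c(C)c3)nc3cc(-c4ccccc4)nn23)cc(OC)c1OC`, has not yet been measured in this assay. Compared with compound 1 the change is 2-((3,4-dimethylphenyl)carbonyl)ethenyl in place of (2-(4-chlorophenyl)ethenyl)carbonyl on an aromatic carbon. In plain terms the carbonyl and the double bond trade places along the chain, and the 4-chlorophenyl group at its end gives way to a 3,4-dimethylphenyl group.

For the measured compounds named here, only the step from compound 1 to compound 3 touches this part of the molecule, and it swapped the aryl group at the end of the chain without any shift beyond the scatter. Going by the values given here, no measured pair reverses the direction of the chain itself, so that part of the change is untested here. Among the compounds with values here, with the one related step flat, the expectation for this assay is no step beyond the scatter: compound 4 is expected to show a 1.2-fold lower number from compound 1 to compound 4 (0.08 log units; within the scatter). Compound 4 is thus estimated at 20000 nM, with a likely range from 7000 nM to 55000 nM.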

Compound 4, half-maximal inhibitory concentration: 10600 nM
Estimate against measurement, compound 4: 1.9-fold (0.28 log units) above; low and high end bracket the measured number.
By their numbers in this assay, from the lowest: compounds 4, 3, 2 and 1 (each within the scatter of the next, the first and the last beyond it).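

In this assay, for the compounds shown here, the position on the shared core that carries the chain gives the first step beyond the scatter in this set: swapping (2-(4-chlorophenyl)ethenyl)carbonyl for 2-((3,4-dimethylphenyl)carbonyl)ethenyl gives a 2.2-fold lower number from compound 1 to compound 4 (0.35 log units; beyond the scatter). The step is modest, but it shows that a change at this position can move the number, whereas the steps from compound 1 to compounds 2 and 3 stayed within the scatter and showed no such movement. No measurement shown here explains the shift, so its cause remains unknown.

The step combines two changes, the reversed order of the carbonyl and double bond and the replacement of 4-chlorophenyl by 3,4-dimethylphenyl, and the compounds shown cannot assign it to either one; a reversed chain still ending in 4-chlorophenyl, or the original chain ending in 3,4-dimethylphenyl, would separate them. Also open, from the compounds shown here alone, is how this position would respond to a chain without its double bond, a longer chain, or a chain ending in an amine or a carboxylic acid instead of an aromatic ring.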